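The compounds below may be only part of what the source reports. "The series", "measured", "known", "first", "only" and "open" are said of these compounds alone.

Of the compounds shown here, two on a shared core have been tested in a functional assay on SW480 cells (Homo sapiens) for antiproliferative activity, read by MTT assay, with a stated time of 48 h; a lower number here means a stronger inhibitor, a higher number a weaker inhibitor. Compound 2 (`CCCCCCC(CCO)n1cnc2c(Cl)ncnc21`) gives 16700 nM, the higher of the two numbers and so the weaker result. Compound 1 (`CCCCCC(CCO)n1cnc2c(Cl)nc(Cl)nc21`) gives 6010 nM, a lower number by a gap beyond the scatter. Compound 3 (`CCCCCCC(CCO)n1cnc2c(Cl)nc(Cl)nc21`) follows from compound 2 by placing chloro in place of hydrogen on an aromatic carbon, between two ring nitrogen atoms: chloro in place of hydrogen on an aromatic carbon. For the measured compounds named here, no measured pair isolates this change, since compound 1 also differs from compound 2 in its chain. Still, compound 1 carries this chloro and gives 6010 nM, so a moderate move to a lower number is expected in this assay. The estimated change is a 3.0-fold lower number from compound 2 to compound 3 (0.48 log units; beyond the scatter). For compound 3 the expected value is 5500 nM, with an estimated range from 2200 nM to 13000 nM.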

Compound 3, half-maximal inhibitory concentration: 12400 nM
Beside the measured number, compound 3's estimate is 2.3-fold (0.35 log units) below it, and the stated range covers the measured number.
By their numbers in this assay, from the lowest: compound 1; then compounds 3 and 2 (each within the scatter of the next).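

In this assay, chloro in place of hydrogen on an aromatic carbon, between two ring nitrogen atoms, gives a 1.3-fold lower number from compound 2 to compound 3 (0.13 log units; within the scatter), so on this longer chain the two compounds cannot be told apart and this position shows no clear response to chloro. The step that does stand out lies in the chain: methyl in place of hydrogen on a saturated chain carbon, six bonds along the chain from an aromatic nitrogen, gives a 2.1-fold higher number from compound 1 to compound 3 (0.31 log units; beyond the scatter), a modest step that separates compound 1 from compound 3 with the chloro present in both. Nothing measured here accounts for either step.

The compounds shown leave open whether an amine or a methoxy group at this position would move the number further than chloro does. They also leave open whether a still shorter chain would extend the modest step seen at the chain, and whether that step holds when hydrogen replaces this chloro.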